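From 4-methylbenzyl to 2-nitrobenzyl: a stability estimate

This account rests on a few compounds, and the source may have more. Where it says the series, first, only, none or still open, it means among the compounds named here.

- Compound 1 `Cc1ccc(CO[P@@]2(=O)OC[C@H]3O[C@@H](n4cnc5c(N)ncnc54)[C@H](O)[C@@H]3O2)cc1`: 9.5 h
- Compound 2 `Nc1ncnc2c1ncn2[C@@H]1O[C@@H]2CO[P@](=O)(OCc3ccc([N+](=O)[O-])cc3)O[C@H]2[C@H]1O`: 9.5 h

In a physicochemical assay for metabolic stability, at 30 degrees C, at pH 6.5 (a higher number here means that the compound lasts longer, a lower number that the compound disappears faster), compound 1 gives 9.5 h, level with compound 2 at 9.5 h. Compound 3 `Nc1ncnc2c1ncn2[C@@H]1O[C@@H]2CO[P@](=O)(OCc3ccccc3[N+](=O)[O-])O[C@H]2[C@H]1O` keeps the core of compound 1 and changes one group: 2-nitrophenyl in place of 4-methylphenyl on a saturated chain carbon bound to an oxygen on an unsaturated carbon. Among the measured compounds shown here, only one measured step bears on this, nitro in place of methyl on an aromatic carbon: no change at the digits printed from compound 1 to compound 2 (within the scatter). For the measured compounds named here, no measured compound carries 2-nitrophenyl, so this evidence is limited. The expected step is no change at the digits printed from compound 1 to compound 3 (within the scatter), with nothing expected beyond the scatter. For compound 3, the estimated half-life in this assay is 9.5 h, with an expected range of 4 h to 20 h.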

Compound 3, half-life: 9.5 h
Compound 3: middle estimate and measured number agree at the digits printed, within the range that was stated.
By their numbers in this assay, from the lowest: compounds 1, 2 and 3 (each within the scatter of the next).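

In this assay, 2-nitrophenyl now has its own measured step against 4-methylphenyl (no change at the digits printed from compound 1 to compound 3 (within the scatter)). It also has one against 4-nitrophenyl (no change at the digits printed from compound 2 to compound 3 (within the scatter)), so the nitro group gives the same reading as either of the two named forms at this place on the shared core. Nothing measured here offers an explanation for these flat readings. The compounds shown carry only methyl or nitro on the phenyl group. As far as these compounds go, how an amine or a carboxylic acid there, or a longer chain in place of the benzyl group, would read remains open.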